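The compounds below may be only part of what the source reports. "The series", "measured", "known", "first", "only" and "open" are said of these compounds alone.

The measured compounds:

compound 1 `COc1ccc(NC(=O)c2ccccn2)c(CN2C(=O)c3ccccc3C2=O)c1`: 1400 nM
compound 2 `CCOc1cccc2c1C(=O)N(Cc1cc(Cl)ccc1NC(=O)c1ccccn1)C2=O`: 280 nM
compound 3 `O=C(Nc1ccc(Cl)cc1CN1C(=O)c2ccccc2C1=O)c1ccco1`: 2300 nM

In an assay on CHO cells for positive allosteric modulation of metabotropic glutamate receptor 5 (Homo sapiens), read by FLIPR (on this read-out higher numbers stand for an effect only at larger amounts of compound and lower numbers for an effect already at smaller amounts), compound 2 gives the lowest of the three numbers; compound 1 lies a fair way above it and compound 3 further still, both gaps beyond the usual scatter. Compound 4 `CCOc1cccc2c1C(=O)N(Cc1cc(Br)ccc1NC(=O)c1ccccn1)C2=O` has not yet been measured in this assay. It differs from compound 2 by bromo in place of chloro on an aromatic carbon. For the measured compounds named here, no pair among the measured compounds shows this kind of change, so there is nothing to calibrate it against; a halogen swap of this sort is expected to move the number little, if at all, beyond the scatter. Compound 4 is therefore estimated at 250 nM, within 110 nM to 600 nM, a step of a 1.1-fold lower number from compound 2 to compound 4 (0.05 log units; within the scatter) that is expected to stay close to compound 2.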

Compound 4, half-maximal effective concentration: 720 nM
For compound 4 the middle estimate is 2.9-fold (0.46 log units) below the measured one, outside the stated range (above it).
By their numbers in this assay, from the lowest: compound 2; then compounds 4, 1 and 3 (each within the scatter of the next, the first and the last beyond it).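

In this assay bromo in place of chloro on this aromatic carbon, para to the ((pyridin-2-yl)carbonyl)amino group, gives a 2.6-fold higher number from compound 2 to compound 4 (0.41 log units; beyond the scatter) as a modest step. For the compounds shown here, this is the first change in a single place among the compounds, and it shows that the number responds even to an exchange of one halogen for another at this position, with chloro giving the lower number of the two. No measurement shown bears on why the two halogens differ.

As far as these compounds go, what fluoro or a nitrile on this carbon would give remains open. So does whether the same swap would have a similar size on the core of compound 3.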